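Bromo to fluoro at the aromatic carbon of the core

The source may report more compounds than this note shows. Statements on the series, on what has been measured and on what is new or still open speak of the compounds shown alone.

Measured so far:
- compound 1, `COc1cc(C(=O)NC2CCN(C)CC2)ccc1Nc1ncc(Br)c(NC2CCCC2)n1`: 3500 nM
- compound 2, `CN1CCN(c2ccc(Nc3ncc(F)c(NC4CCCC4)n3)cc2)CC1`: 20000 nM

Two compounds have numbers in a functional assay on HeLa cells (Homo sapiens) for cytotoxicity, read by MTT assay, with a stated time of 48 h; a lower number here means a stronger inhibitor, a higher number a weaker inhibitor. Compound 1 stands at the lower of the two; compound 2 sits at a higher number, and the gap between them lies beyond the scatter. The two compounds differ in more than one place, so the gap cannot be tied to a single change.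

Compound 3, `COc1cc(C(=O)NC2CCN(C)CC2)ccc1Nc1ncc(F)c(NC2CCCC2)n1`, is not yet measured. It differs from compound 1 in one place: fluoro in place of bromo on an aromatic carbon. The exchange keeps the hydrogen-bond donor and acceptor counts and the charge unchanged; only the halogen at that aromatic carbon of the core is swapped.

Going by the values given here, no measured pair shows this exact step, so the expected size rests on judgement alone. The swap is expected to move compound 3 toward a higher number than compound 1, most likely a moderate step beyond the scatter rather than a large one, giving an expected step of a 2.3-fold higher number from compound 1 to compound 3 (0.36 log units; beyond the scatter). For compound 3 the expected value in this assay is 8000 nM, within a range of 3000 nM to 25000 nM.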

Compound 3, half-maximal inhibitory concentration: 2200 nM
Beside the measured number, compound 3's estimate is 3.6-fold (0.56 log units) above it; the whole stated range lies above it.
By their numbers in this assay, from the lowest: compounds 3 and 1 (each within the scatter of the next); then compound 2.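

In this assay, fluoro in place of bromo on the aromatic carbon ortho to a cyclopentylamino group gives a 1.6-fold lower number from compound 1 to compound 3 (0.20 log units; within the scatter), so at this position, with the rest of the molecule held fixed, the two halogens cannot be told apart in this read-out. Compound 3 carries the same fluoro as compound 2, so the halogen does not separate those two compounds; they differ elsewhere, and the gap between them cannot be tied to any single change. Nothing available here explains why the two halogens read alike.

On these data alone, only two halogens at this carbon have numbers, so it stays open whether hydrogen, a methyl group, a nitrile or a trifluoromethyl group there would also stay within the scatter of compound 1 in this assay. Also open, as far as these compounds go, is whether the same exchange would read alike with a cyclohexylamino group or a longer alkylamino chain in place of the cyclopentylamino group.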